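Pyridine to Thiophene at the Core: Compound 4

This account rests on a few compounds, and the source may have more. Where it says the series, first, only, none or still open, it means among the compounds named here.

Of the compounds shown here, three sharing one core have been tested in an assay on isolated protein for inhibition of DNA topoisomerase 1 (Homo sapiens), with a stated time of 30 min, tested at 100 uM; on this read-out lower numbers stand for a weaker effect and higher numbers for a stronger effect at the one concentration tested. Compound 1 `Oc1ccc(-c2cc(-c3ccccn3)nc(-c3ccccc3Cl)c2)cc1` gives 5.2%, compound 3 `Oc1ccc(-c2cc(-c3ccncc3)nc(-c3ccccc3Cl)c2)cc1` gives 9.9%, and compound 2 `Oc1cccc(-c2cc(-c3ccncc3)nc(-c3cccc(Cl)c3)c2)c1` gives 0%. The number for compound 2 is the smallest of the three, yet it sits within the scatter of both others, so no ordering can be read from it. Among the compounds with values here, the only single change measured, a number 4.7 percentage points higher from compound 1 to compound 3 (within the scatter), is within the scatter as well.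

Compound 4 `Oc1cccc(-c2cc(-c3cccc(Cl)c3)nc(-c3cccs3)c2)c1` is not yet measured. It differs from compound 2 by thiophen-2-yl in place of pyridin-4-yl on an aromatic carbon. Within the data shown here, no measured step involves a thiophen-2-yl group, so nothing directly bears on this change; the one known step, from compound 1 to compound 3, concerns a different exchange and was within the scatter. The expectation is therefore a step of a number 5 percentage points higher from compound 2 to compound 4 (within the scatter) in this assay, not beyond the scatter in either direction. Compound 4 is estimated at 5%, within a range from 0% to 20%.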

Compound 4, a percentage reported as inhibition, at one concentration (the size of the read-out at that concentration, not a potency): 7.6%
Estimate against measurement, compound 4: 2.6 percentage points below, within the range that was stated.
By their numbers in this assay, from the lowest: compounds 2, 1, 4 and 3 (each within the scatter of the next).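

In this assay, thiophen-2-yl in place of pyridin-4-yl next to the ring nitrogen gives a number 7.6 percentage points higher from compound 2 to compound 4 (within the scatter). Within the data shown here, this extends what the earlier compounds showed: there the only step was between two pyridine groups, a number 4.7 percentage points higher from compound 1 to compound 3 (within the scatter), whereas here a five-membered aromatic ring with sulfur replaces a six-membered one with nitrogen, and the step still does not leave the scatter. Nothing measured accounts for this result or links it to either ring.

The four compounds shown give numbers that stay within the scatter of one another in sequence, so it remains open whether any change at this position can move the read-out beyond the scatter. On these data alone, whether an amine or a carboxylic acid in this place would do so is also open.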